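Methylsulfonyl for Acetamido on Two Related Cores

The compounds below may be only part of what the source reports. "The series", "measured", "known", "first", "only" and "open" are said of these compounds alone.

In a physicochemical assay for lipophilicity, at pH 7.4 (on this read-out higher numbers stand for higher lipophilicity and lower numbers for lower lipophilicity), the measured compounds stand as follows:
compound 1 `CC(=O)Nc1ccccc1OCc1cc(C)nc(-c2ccccn2)n1`: 1.6
compound 2 `CC(=O)Nc1ccc(OCc2cc(C)nc(-c3ccccn3)n2)cc1`: 1.9
compound 3 `Cc1cc(COc2ccccc2S(C)(=O)=O)nc(-c2ccccn2)n1`: 1.5

Compound 3 differs from compound 1 by one change, (methylsulfonyl in place of acetamido on an aromatic carbon), and in this assay this made a step of a number 0.10 log units lower from compound 1 to compound 3 (within the scatter). Compound 2 has the same atoms as compound 1, joined differently; the difference between the two cores is not broken down here. Compound 4 `Cc1cc(COc2ccc(S(C)(=O)=O)cc2)nc(-c2ccccn2)n1` carries the same kind of change on the core of compound 2: methylsulfonyl in place of acetamido on an aromatic carbon. The place is not the same word for word: in compound 3 the group sits ortho to a large group, in compound 4 para to a large group. Compound 4 is expected to show a step of a number 0.10 log units lower from compound 2 to compound 4 (within the scatter) in this assay, which rests on the step from compound 1 to compound 3, a number 0.10 log units lower from compound 1 to compound 3 (within the scatter). Compound 4 is therefore estimated at 1.8, between 1.5 and 2.1.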

Compound 4, distribution coefficient: 1.5
Compound 4: the middle estimate sits 0.30 log units above what was measured; the measured number falls inside the stated range.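

In this assay, methylsulfonyl in place of acetamido gives a number 0.40 log units lower from compound 2 to compound 4 (beyond the scatter) on one core, a modest step beyond the scatter, while the same change gives a number 0.10 log units lower from compound 1 to compound 3 (within the scatter) on the other, a step within the scatter. The size of the step on one core therefore did not carry over to the other, although a single pair on each core shows no rule for the series. No evidence is at hand on why the two steps differ.

The compounds shown leave open how other groups would behave on these two cores. As far as these compounds go, whether an amine or a carboxylic acid in place of acetamido would give matching steps on both remains unknown.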